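Replacing 4-fluorobenzyl with 1-phenylethyl: working notes

The compounds below may be only part of what the source reports. "The series", "measured", "known", "first", "only" and "open" are said of these compounds alone.

Compound 1 `Cc1noc(-c2nc(C)c3c(c2N)C(=O)N(Cc2ccc(F)cc2)C3=O)n1` gives < 5000 nM in a physicochemical assay for solubility, using the shake flask method, in simulated intestinal fluid, measured as kinetic solubility, with a stated time of 2 h, at 25 degrees C, at pH 6.5 (a lower number here means a less soluble compound, a higher number a more soluble compound), which is a limit of the assay and not a number. Compound 2 `Cc1noc(-c2nc(C)c3c(c2N)C(=O)N(Cc2ccc(-c4ccncc4)cc2)C3=O)n1` gives < 5000 nM, also a limit. Compound 3 `Cc1noc(-c2nc(C)c3c(c2N)C(=O)N(Cc2ccc(OC(F)(F)F)cc2)C3=O)n1` gives < 5000 nM, again a limit. The series therefore stands at the limit of < 5000 nM in this assay, at which 3 of the 3 values shown sit.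

Compound 4 `Cc1noc(-c2nc(C)c3c(c2N)C(=O)N(C(C)c2ccccc2)C3=O)n1` carries 1-phenylethyl in place of 4-fluorobenzyl on an amide-type nitrogen in a ring.

The nearest measured changes replace the fluoro group on an aromatic carbon, not the whole group on that nitrogen. They are a step that the two limits leave unreadable from compound 1 to compound 2 and a step that the two limits leave unreadable from compound 1 to compound 3. The remaining step, a step that the two limits leave unreadable from compound 2 to compound 3, is no more informative. None of these steps gives a size to carry over, so no direction can be assigned in this assay.

The expected change is no step beyond the scatter, and the estimate means a step that the limit leaves unreadable from compound 1 to compound 4. Compound 4 is estimated at 3000 nM, with an expected range from 1000 nM to 6000 nM.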

Compound 4, solubility: 10900 nM
For compound 4 the middle estimate is 3.6-fold (0.56 log units) below the measured one; measured number outside the range, above it.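

Going by these compounds alone, exchanging 4-fluorobenzyl for 1-phenylethyl on the amide-type nitrogen in a ring gives an at least 2.1-fold higher number from compound 1 to compound 4 (0.33 log units; beyond the scatter) in this assay, the only readable step and one beyond the scatter. The group on that nitrogen is therefore a place where the read-out can leave the limit, which the changes on the aromatic carbon, all unreadable, could not show: the limit of < 5000 nM in this assay, at which 3 of the 4 values shown sit. The exchange removes the fluoro group and adds a methyl at once, so the step belongs to the two changes taken together.

Which of the two changes carries the step stays open, and plain benzyl on that nitrogen would separate them. Also open, going by these compounds, is how the number responds to an amine or a carboxylic acid on the phenyl ring of 1-phenylethyl.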